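A Bulkier Ester on a Shorter Linker

This account rests on a few compounds, and the source may have more. Where it says the series, first, only, none or still open, it means among the compounds named here.

Of the compounds shown here, three sharing one core have been measured in a functional assay on NB-4 cells (Homo sapiens) for inhibition, read by MTT assay, with a stated time of 48 h; a lower number here means a stronger inhibitor, a higher number a weaker inhibitor. Compound 1, `CCCC(=O)OCCCCOC(=O)c1ccc(C(=O)Nc2ccc3c(c2)C(C)(C)CCC3(C)C)cc1`, gives 23200 nM. Compound 2, `Cc1cc2c(cc1C(=O)c1ccc(C(=O)OCCCOC(=O)c3ccc(C(=O)Nc4ccc5c(c4)C(C)(C)CCC5(C)C)cc3)cc1)C(C)(C)CCC2(C)C`, gives 112000 nM, and compound 3, `C=C(c1ccc(C(=O)OCCCCOC(=O)c2ccc(C(=O)Nc3ccc4c(c3)C(C)(C)CCC4(C)C)cc2)cc1)c1cc2c(cc1C)C(C)(C)CCC2(C)C`, gives 650000 nM. Compound 1 stands lowest of the three; its gap to compound 2 and its larger gap to compound 3 both lie beyond the scatter of repeated measurements, so compound 1 reads as the strongest inhibitor among them.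

Compound 4, `CCCC(CCC)C(=O)OCCCOC(=O)c1ccc(C(=O)Nc2ccc3c(c2)C(C)(C)CCC3(C)C)cc1`, is the next compound to be measured. It differs from compound 1 in one place: ((1-propylbutyl)carbonyl)oxy in place of ((propylcarbonyl)oxy)methyl on a saturated chain carbon, three bonds along the chain from an oxygen next to a carbonyl group. The change lies in the ester tail alone, a larger acyl group on a shorter chain, while the shared core and the amide are left untouched.

Going by the values given here, no measured pair in this set isolates such a change, so there is no direct precedent for its size. Given that only the ester tail moves, the expected step of a 1.1-fold lower number from compound 1 to compound 4 (0.02 log units; within the scatter) is small and may well fall within the scatter, in either direction. The estimate for compound 4 in this assay is 22000 nM, with a range from 7000 nM to 70000 nM.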

Compound 4, half-maximal inhibitory concentration: > 1000000 nM
Compound 4: only a limit was reported (the forecaster's own chance of this, stated with the estimate: 5%); middle value at least 45-fold (1.65 log units) from the limit.
By their numbers in this assay, from the lowest: compound 1; then compound 2; then compound 3. At a limit, above all of these: compound 4.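

Compound 4 reads only as a limit of the assay, not as a number: the limit of > 1000000 nM in this assay, at which 1 of the 4 values shown sits. Placing ((1-propylbutyl)carbonyl)oxy in place of ((propylcarbonyl)oxy)methyl on this saturated chain carbon gives an at least 43-fold higher number from compound 1 to compound 4 (1.63 log units; beyond the scatter) in this assay, the first step in the set between two compounds that differ in one place. It shows that a change confined to the ester tail, with the shared core and the amide untouched, is enough to move the reading well beyond the scatter, so this position does not tolerate every ester tail equally.

The step joins two things, since cut one bond further out it reads as 3-((propylcarbonyl)oxy)propyl going to 2-(((1-propylbutyl)carbonyl)oxy)ethyl, and the compounds shown do not say whether the acyl group or the chain carries the loss. On these data alone, how far the reading would move with another group at this position, such as a carboxylic acid, an amine or a longer chain bearing the same acyl group, also stays open.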